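A few compounds are considered here, and "the series" means these few. Any claim that something is new, unique, unknown or untested is made for them only; others in the source may bear on it.

Of the compounds shown here, two with a shared core have been measured in an assay on isolated protein for binding affinity to vitamin D3 receptor (Homo sapiens), with a stated time of 4 h; on this read-out higher numbers stand for weaker inhibition and lower numbers for stronger inhibition. Compound 1 `CCn1c(C(=O)NCC(OC)OC)ccc1C(CC)(CC)c1ccc(OCC(O)C(C)(C)C)c(C)c1` gives 5240 nM. Among the measured compounds shown here, compound 2 `CC[C@@H](C)[C@H](NC(=O)c1ccc(C(CC)(CC)c2ccc(OCC(O)C(C)(C)C)c(C)c2)n1CC)C(=O)O` gives 389 nM, the lowest of the two numbers, with compound 1 as its only neighbour. For the measured compounds named here, the single step between them, a 13-fold lower number from compound 1 to compound 2 (1.13 log units; beyond the scatter), runs from a 2,2-dimethoxyethyl group to a 1-carboxy-2-methylbutyl group on the amide-type nitrogen.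

Compound 3 `CCOc1ccc(NC(=O)c2ccc(C(CC)(CC)c3ccc(OCC(O)C(C)(C)C)c(C)c3)n2CC)cc1` is the next compound to be measured. It differs from compound 2 in one place: 4-ethoxyphenyl in place of 1-carboxy-2-methylbutyl on an amide-type nitrogen. The step from compound 1 to compound 2 is the only measured one that touches this position, and it was large; there, installing the 1-carboxy-2-methylbutyl group brought the number down sharply. Compound 3 takes that same group away again and puts a 4-ethoxyphenyl group in its place, a group unlike either of the two measured ones, so the direction is uncertain but a rise back toward compound 1 appears more likely than a further fall. The expected step is therefore a 7.7-fold higher number from compound 2 to compound 3 (0.89 log units; beyond the scatter), and in this assay compound 3 is estimated to give 3000 nM, within a range of 700 nM to 13000 nM.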

Compound 3, half-maximal inhibitory concentration: 9250 nM
For compound 3 the middle estimate is 3.1-fold (0.49 log units) below the measured one, and the stated range covers the measured number.
By their numbers in this assay, from the lowest: compound 2; then compounds 1 and 3 (each within the scatter of the next).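

Replacing the 1-carboxy-2-methylbutyl group on the amide-type nitrogen with 4-ethoxyphenyl gives a 24-fold higher number from compound 2 to compound 3 (1.38 log units; beyond the scatter) in this assay, so the low number of compound 2 does not come with just any larger group at this position. The two other groups measured here cannot be told apart, since the comparison gives a 1.8-fold higher number from compound 1 to compound 3 (0.25 log units; within the scatter) even though 4-ethoxyphenyl has an aromatic ring and 2,2-dimethoxyethyl has none. Among these three compounds, only the 1-carboxy-2-methylbutyl group stands out, but no supporting measurement explains this result.

The compounds shown do not separate the parts of that group, so it remains open whether the low number depends on the carboxylic acid, on the branched 2-methylbutyl chain, or on both together. A plain 2-methylbutyl chain without the acid, a phenyl ring carrying a carboxylic acid instead of the ethoxy group, or the same group with its two stereocentres reversed would each test a different one of these possibilities.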